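The source may report more compounds than this note shows. Statements on the series, on what has been measured and on what is new or still open speak of the compounds shown alone.

Measured in a functional assay on NCI-H460 cells (Homo sapiens) for cytotoxicity, read by MTT assay, with a stated time of 72 h; a higher number here means a weaker inhibitor, a lower number a stronger inhibitor
- compound 1 `CN(C)Cc1ccc2nc(NC(=O)N/N=C/c3cn(Cc4ccccc4Cl)c4ccccc34)sc2c1` gives 1600 nM
- compound 2 `CN(C)Cc1ccc2nc(NC(=O)N/N=C3\C(=O)Nc4ccc(Cl)cc43)sc2c1` gives 1170 nM
- compound 3 `CN(C)Cc1ccc2nc(NC(=O)N/N=C/c3cn(Cc4ccc(C(C)(C)C)cc4)c4ccccc34)sc2c1` gives 810 nM

Compound 2 at 1170 nM sits within the usual scatter of both other compounds, so these numbers cannot rank the three with confidence.

Compound 4 `CN(C)Cc1ccc2nc(NC(=O)N/N=C3\C(=O)Nc4ccc(F)cc43)sc2c1` has not yet been measured. It matches compound 2 except at one site: fluoro in place of chloro on an aromatic carbon. In words, this is fluoro in place of chloro on an aromatic carbon of a six-membered aromatic ring of carbon only, part of a fused or bridged system of two rings.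

Among the compounds with values here, no measured step makes this exchange, so the data offer no direct reading of it. Within the data shown here, the only measured step replaces 2-chlorophenyl with 4-(tert-butyl)phenyl at a different site, and it gives a 2.0-fold lower number from compound 1 to compound 3 (0.30 log units; within the scatter). Even that exchange of a whole group stays within the scatter, and it says nothing about direction here. No step beyond the scatter is therefore expected in this assay, and compound 4 should stay close to compound 2 at 1170 nM for now. The expected change is a 1.0-fold higher number from compound 2 to compound 4 (0.01 log units; within the scatter) and lies inside the scatter. For compound 4 the estimate is 1200 nM with an expected range from 600 nM to 2400 nM.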

Compound 4, half-maximal inhibitory concentration: 1550 nM
Beside the measured number, compound 4's estimate is 1.3-fold (0.11 log units) below it; the range from low to high includes it.
By their numbers in this assay, from the lowest: compounds 3, 2, 4 and 1 (each within the scatter of the next).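

In this assay, within the data shown here, the pair of compound 2 and compound 4 gives the first direct reading of the halogen on an aromatic carbon of the six-membered aromatic ring of carbon only, the site that is meta to a fused ring and para to a fused ring. Exchanging chloro for fluoro there gives a 1.3-fold higher number from compound 2 to compound 4 (0.12 log units; within the scatter), so the two halogens cannot be told apart at this site in this cell test, even though each is a single heavy atom of a different element and neither adds a hydrogen-bond donor, a hydrogen-bond acceptor or a charge. Nothing available explains why this exchange stays so small.

The compounds shown carry only chloro or fluoro at this site, so they cannot say whether the number would leave the scatter with a larger or very different group there, such as a methoxy group, a nitrile, an amine or a carboxylic acid. On these data alone, it also remains open whether a plain hydrogen at this site would read the same as either halogen, which would show whether a halogen is needed there at all.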